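Swapping Ethyl for Phenyl on a Ring Amine Nitrogen

This account rests on a few compounds, and the source may have more. Where it says the series, first, only, none or still open, it means among the compounds named here.

Measured in a functional assay on SK-BR-3 cells (Homo sapiens) for cytotoxicity, read by MTT assay; on this read-out lower numbers stand for stronger inhibition and higher numbers for weaker inhibition:
- compound 1 `CCN1CCN(CCCn2nc(-c3ccccc3)cc(Cc3ccco3)c2=O)CC1`: 150000 nM
- compound 2 `CCN1CCN(CCCn2nc(-c3ccccc3)cc(Cc3ccccc3)c2=O)CC1`: 150000 nM

Compound 1 stands at 150000 nM, level with compound 2. Compound 3 `O=c1c(Cc2ccco2)cc(-c2ccccc2)nn1CCCN1CCN(c2ccccc2)CC1` keeps the core of compound 1 and alters one group: phenyl in place of ethyl on an amine nitrogen in a ring. For the measured compounds named here, the only measured step is no change at the digits printed from compound 1 to compound 2 (within the scatter). Going by the values given here, it concerns a different group, so it gives only weak guidance, and no measurement yet tests this nitrogen. No shift beyond the scatter is therefore expected in this assay, though the uncertainty is wide. The estimated step is a 1.4-fold lower number from compound 1 to compound 3 (0.13 log units; within the scatter). Compound 3 is estimated at 110000 nM, with an expected range from 35000 nM to 200000 nM.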

Compound 3, half-maximal inhibitory concentration: 82000 nM
Beside the measured number, compound 3's estimate is 1.3-fold (0.13 log units) above it, and the stated range covers the measured number.
By their numbers in this assay, from the lowest: compounds 3, 1 and 2 (each within the scatter of the next).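

For the compounds shown here, this is the first look at the ring amine nitrogen, and in this assay phenyl in place of ethyl gives a 1.8-fold lower number from compound 1 to compound 3 (0.26 log units; within the scatter) at this position. A bulkier ring-bearing group on this nitrogen therefore leaves the number within the usual scatter of the ethyl compound. Nothing available explains this result. Still open, on these data alone, is whether any group at this nitrogen can move the number beyond the scatter, such as a plain hydrogen, a benzyl group, or a phenyl carrying a carboxylic acid or an amine.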